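A few compounds are considered here, and "the series" means these few. Any claim that something is new, unique, unknown or untested is made for them only; others in the source may bear on it.

In an ADME assay on cells (Astrocyte, Homo sapiens) for cytotoxicity, read by WST assay, with a stated time of 72 h (a lower number here means a stronger inhibitor, a higher number a weaker inhibitor), compound 1 `O=C(Nc1cccc(Cl)c1)Nc1cc2ncncc2cc1OCc1ccccc1Cl`, which carries the 3-chlorophenyl group, gives > 10000 nM, a limit of the assay and not a number. Compound 2 `O=C(Nc1ccccc1F)Nc1cc2ncncc2cc1OCc1ccccc1` gives > 10000 nM, also a limit. Within the data shown here, compound 3 `O=C(Nc1ccc(C(F)(F)F)cc1)Nc1cc2ncncc2cc1OCc1ccccc1` gives 9200 nM, the only true number so far. Most of the picture therefore rests on (the limit of > 10000 nM in this assay, at which 2 of the 3 values shown sit). Compound 4 `O=C(Nc1cccc(Cl)c1)Nc1cc2ncncc2cc1OCc1ccccc1` has one change from compound 3: 3-chlorophenyl in place of 4-(trifluoromethyl)phenyl on an amide-type nitrogen. The only measured step on this nitrogen is an at least 1.0-fold lower number from compound 2 to compound 3 (0.03 log units; that floor lies within the scatter), so exchanging the aryl group there has not yet shown a clear effect. The expected result is no shift beyond the scatter, with an estimated 1.1-fold higher number from compound 3 to compound 4 (0.04 log units; within the scatter). For compound 4, the estimate is 10000 nM, with an expected range of 5000 nM to 20000 nM.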

Compound 4, half-maximal inhibitory concentration: 7400 nM
The estimate for compound 4 lay 1.4-fold (0.13 log units) above the measured number; the measured number falls inside the stated range.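

In this assay, among these compounds, 3-chlorophenyl in place of 4-(trifluoromethyl)phenyl on the amide-type nitrogen gives a 1.2-fold lower number from compound 3 to compound 4 (0.09 log units; within the scatter), the first comparison at this position between two true numbers. 3-Chlorophenyl in place of 2-fluorophenyl gives an at least 1.3-fold lower number from compound 2 to compound 4 (0.13 log units; that floor lies within the scatter), and hydrogen in place of chloro on an aromatic carbon gives an at least 1.3-fold lower number from compound 1 to compound 4 (0.13 log units; that floor lies within the scatter). Both of these steps remain floors only, because each starts from a compound at the limit: the limit of > 10000 nM in this assay, at which 2 of the 4 values shown sit.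

Going by these compounds, it remains open whether a carboxylic acid or an amine on the aryl ring, or a longer chain in its place on this nitrogen, would move the number beyond the scatter.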